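A few compounds are considered here, and "the series" means these few. Any claim that something is new, unique, unknown or untested is made for them only; others in the source may bear on it.

Measured so far in a functional assay on A549 cells (Homo sapiens) for inhibition, read by MTT assay, with a stated time of 72 h; a lower number here means a stronger inhibitor, a higher number a weaker inhibitor:
Compound 1, `C=CC(=O)Nc1cc(Nc2nc3c(c(-c4cn(C)c5ccccc45)n2)CSCC3)c(OC)cc1N(C)CCN(C)C`, gives 506 nM.
Compound 2, `C=C(Cl)C(=O)Nc1cc(Nc2nc3c(c(-c4cn(C)c5ccccc45)n2)CSCC3)c(OC)cc1N(C)CCN(C)C`, gives 716 nM.
Compound 3, `C=CC(=O)Nc1cc(Nc2nc3c(c(-c4cn(C)c5ccccc45)n2)CS(=O)(=O)CC3)c(OC)cc1N(C)CCN(C)C`, gives 8690 nM.

Compounds 1 and 2 share one core and differ in a single spot: chloro in place of hydrogen on a double-bonded chain carbon bound to a carbonyl carbon. That change made a 1.4-fold higher number from compound 1 to compound 2 (0.15 log units; within the scatter), so the two values sit within the usual scatter of this assay and neither can be called the stronger inhibitor. Compound 3 carries a different core; how its core differs from that of compound 1 is not broken down here. Its number is the highest of the three, and its gaps to compound 1 and to compound 2 both lie beyond the scatter.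

Compound 4, `C=C(Cl)C(=O)Nc1cc(Nc2nc3c(c(-c4cn(C)c5ccccc45)n2)CS(=O)(=O)CC3)c(OC)cc1N(C)CCN(C)C`, has not yet been measured. It relates to compound 3 exactly as compound 2 relates to compound 1: chloro in place of hydrogen on a double-bonded chain carbon bound to a carbonyl carbon, at the same place in the same words, so this is the same change made on the other core. Because the earlier step was a 1.4-fold higher number from compound 1 to compound 2 (0.15 log units; within the scatter), the expected step on the new core is a 1.3-fold higher number from compound 3 to compound 4 (0.10 log units; within the scatter), a small shift that stays within the scatter. Compound 4 is therefore estimated at 11000 nM in this assay, with an expected range from 5000 nM to 25000 nM.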

Compound 4, half-maximal inhibitory concentration: 881 nM
Compound 4: middle estimate off by 12-fold (1.10 log units), on the high side; measured number below the stated range.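

In this assay, chloro in place of hydrogen on a double-bonded chain carbon bound to a carbonyl carbon gives a 9.9-fold lower number from compound 3 to compound 4 (0.99 log units; beyond the scatter), a clear drop in the number and so a stronger inhibitor on this core. The same swap made no readable difference on the core of compound 1, so its effect cannot simply be carried from one core to the other at the same size: the same change on two cores in this assay, a 1.4-fold higher number (0.15 log units; within the scatter) from compound 1 to compound 2 and a 9.9-fold lower number (0.99 log units; beyond the scatter) from compound 3 to compound 4, 14-fold (1.14 log units) apart, beyond the scatter of two such steps. Within the data shown here, this shows that the effect of the swap depends on the core it sits on, but with only two pairs and one cell assay, it does not show why the two cores differ or which of them is the more typical case.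

The compounds shown leave open how other groups at this place, such as fluoro, bromo or methyl, would behave on each core. They also leave open whether a further core would respond like the pair compound 1 and compound 2 or like the pair compound 3 and compound 4.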